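A further methoxy at the assay limit

The source may hold more compounds than are shown below. What is called first, only, known or untested is meant among the compounds shown, and "the series" means these compounds.

In an ADME assay on BJ cells (Homo sapiens) for cytotoxicity, read by MTT assay, with a stated time of 72 h (on this read-out lower numbers stand for stronger inhibition and higher numbers for weaker inhibition), compound 1 (`COc1ccccc1CNc1ncnc2c1ncn2C1CCCCO1`) gives > 100000 nM as a limit of the assay. Compound 2 (`COc1ccc(OC)c(CNc2ncnc3c2ncn3C2CCCCO2)c1`) gives > 100000 nM as a limit too, so it stands without a number. Among the compounds with values here, compound 3 (`COc1cc(OC)c(OC)cc1CNc1ncnc2c1ncn2C1CCCCO1`) differs from it by methoxy in place of hydrogen on an aromatic carbon as its single change. The one comparable replacement is a step that the two limits leave unreadable from compound 1 to compound 2 and offers no size to carry over. Within the data shown here, with the limit of > 100000 nM in this assay, at which 2 of the 2 values shown sit, as the only guide, no step beyond the scatter is expected in this assay and no direction is favoured. The expected step is a number no higher from compound 2 to compound 3 (the limit leaves the size open) as a working figure. For compound 3 the estimate is 100000 nM within an expected range of 50000 nM to 200000 nM and a further limit is likely.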

Compound 3, half-maximal inhibitory concentration: > 100000 nM
Compound 3 ended at the assay's limit; the forecaster's own chance of this, stated with the estimate: 85%; the middle value sits exactly at the limit.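

Within the data shown here, compound 2 and compound 3 both stand only as limits in this assay; no step between them can be read. The compounds shown leave open where their true values lie and whether a further methoxy changes the read-out at all.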